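Replacing the 3-hydroxy-4-methoxyphenyl group of compound 2

This account rests on a few compounds, and the source may have more. Where it says the series, first, only, none or still open, it means among the compounds named here.

In a functional assay on U-251 cells (Homo sapiens) for cytotoxicity (on this read-out higher numbers stand for weaker inhibition of growth and lower numbers for stronger inhibition of growth), compound 1 `COc1ccc(C2=C(c3cc(OC)c(OC)c(OC)c3)CC3CCCN3C2=O)cc1O` gives only a limit, > 100000 nM. Among the compounds with values here, compound 2 `COc1ccc(C2=C(c3ccc(SC)cc3)CC3CCCN3C2=O)cc1O` gives 5000 nM, the only actual number so far. Compound 3 `CSc1ccc(C2=C(c3ccc(C)c(C)c3)C(=O)N3CCCC3C2)cc1` carries 3,4-dimethylphenyl in place of 3-hydroxy-4-methoxyphenyl on a double-bonded ring carbon. Within the data shown here, no two measured compounds differ in just one place, so the data offer no direct guide to this change. A moderate loss is tentatively expected, and the estimated step is a 4.0-fold higher number from compound 2 to compound 3 (0.60 log units; beyond the scatter), towards weaker inhibition of growth in this assay. For compound 3 the expected value is 20000 nM, with a range of 4000 nM to 80000 nM.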

Compound 3, concentration for 50% growth inhibition: 10000 nM
Compound 3: middle estimate off by 2.0-fold (0.30 log units), on the high side; measured number inside the range.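

The change reads as a 2.0-fold higher number from compound 2 to compound 3 (0.30 log units; within the scatter) in this assay, so on this double-bonded ring carbon 3,4-dimethylphenyl can stand in place of 3-hydroxy-4-methoxyphenyl with no shift beyond the scatter. The hydrogen-bond donor and acceptors counted on the leaving group are therefore not required for the growth inhibition seen with compound 2 in this assay. Nothing measured here gives a reason for this result.

The compounds shown leave open whether a phenyl ring carrying an amine or a carboxylic acid at this position would keep this level of growth inhibition.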